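Adding an Acid to the Side Chain of Compound 2

The compounds below may be only part of what the source reports. "The series", "measured", "known", "first", "only" and "open" are said of these compounds alone.

Of the compounds shown here, two of a shared core have been measured so far. Compound 1 `CCCn1nc(-c2cccnc2)c2ccccc2c1=O` gives 3160 nM in a functional assay (trachea) with Cavia porcellus as the target; a lower number here means a stronger inhibitor, a higher number a weaker inhibitor. Compound 2 `COCCn1nc(-c2cccnc2)c2ccccc2c1=O`, which differs only in its side chain, gives 9330 nM. Among the compounds with values here, the one step between them, a 3.0-fold higher number from compound 1 to compound 2 (0.47 log units; beyond the scatter), is the only comparison available, so compound 2 stands as the higher of the two numbers, that is, the weaker inhibitor of the pair.

Compound 3 `O=C(O)CCCn1nc(-c2cccnc2)c2ccccc2c1=O` carries the next change on the same side chain: carboxymethyl in place of methoxy on a saturated chain carbon, two bonds along the chain from an aromatic nitrogen. Within the data shown here, no measured step covers this exact change. Among the measured compounds shown here, the only step on record concerns the same position and shows that lengthening the chain with an oxygen-bearing group raised the number for compound 2 compared with compound 1. That step is a modest one, and it points toward the side chain mattering rather than being neutral. A further enlargement in the same place is therefore expected to leave the number similar or somewhat higher, so the step of a 1.6-fold higher number from compound 2 to compound 3 (0.21 log units; within the scatter) is expected. For compound 3 the estimate is 15000 nM, with a plausible range from 4000 nM to 60000 nM.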

Compound 3, half-maximal inhibitory concentration: > 100000 nM
Compound 3 gave a limit, no number; the forecaster's own chance of this, stated with the estimate: 15%; at least 6.6-fold (0.82 log units) between middle value and limit.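

The reading for compound 3 in this assay is a limit of the assay and not a number: the limit of > 100000 nM in this assay, at which 1 of the 3 values shown sits. Even read from that limit, carboxymethyl in place of methoxy gives an at least 10-fold higher number from compound 2 to compound 3 (1.03 log units; beyond the scatter) and carboxy in place of hydrogen on a saturated chain carbon, three bonds along the chain from an aromatic nitrogen, gives an at least 31-fold higher number from compound 1 to compound 3 (1.50 log units; beyond the scatter). The earlier compounds shown here showed only a modest step at this position, whereas these larger steps show that a change to this side chain can weaken inhibition far more than methoxy in place of methyl did, with the shared core unchanged.

The compounds shown leave open whether the loss goes with the carboxy group itself or with the greater length of the 3-carboxypropyl chain, as both differ from the 2-methoxyethyl chain of compound 2 at once. A plain butyl chain would test length without the acid, while a methyl ester or an amine at the end of the same chain would test what the end group contributes at that length.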